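Adding an Isopropyl Arm to a Weak Kinase Inhibitor

A few compounds are considered here, and "the series" means these few. Any claim that something is new, unique, unknown or untested is made for them only; others in the source may bear on it.

In an assay on isolated protein for inhibition of interferon-induced, double-stranded RNA-activated protein kinase (Homo sapiens), read by luminescence, with a stated time of 10 min (a lower number here means a stronger inhibitor, a higher number a weaker inhibitor), compound 1 `Cc1[nH]c2ccccc2c1-c1ccnc(NCCO)n1` gives 11000 nM. Within the data shown here, its only measured neighbour, compound 2 `OCCNc1nccc(-c2c[nH]c3ccccc23)n1`, gives 11000 nM, and the step from compound 1 to compound 2 is no change at the digits printed from compound 1 to compound 2 (within the scatter), so compound 1 stands level with compound 2. Compound 3 `Cc1[nH]c2ccccc2c1-c1ccnc(NC(CO)C(C)C)n1` carries isopropyl in place of hydrogen on a saturated chain carbon bound to a nitrogen on an aromatic ring and a saturated chain carbon. Among the measured compounds shown here, no measured step touches this part of the chain, so the single known step gives no guide to direction or size, and any expectation rests on the change alone. The step from compound 1 to compound 3 is expected to be a 1.4-fold lower number from compound 1 to compound 3 (0.14 log units; within the scatter). For compound 3 the estimated value is 8000 nM, in a range from 2000 nM to 30000 nM.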

Compound 3, half-maximal inhibitory concentration: 50000 nM
The estimate for compound 3 lay 6.3-fold (0.80 log units) below the measured number, and the stated range ends below it.
By their numbers in this assay, from the lowest: compounds 1 and 2 (each within the scatter of the next); then compound 3.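

Isopropyl in place of hydrogen on this saturated chain carbon gives a weaker inhibitor in this assay (a 4.5-fold higher number from compound 1 to compound 3 (0.66 log units; beyond the scatter)), whereas the earlier step, made at a different place, left the number unchanged. This chain position therefore responds to added carbon, and this particular branch moves the number the wrong way. Nothing at hand bears on why the number rose. From the compounds shown here alone, whether a smaller methyl group on this carbon would cost less remains open, as does whether an amine or a carboxylic acid there would give a lower number. The same isopropyl change on compound 2 is also an open question.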